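The source may report more compounds than this note shows. Statements on the series, on what has been measured and on what is new or still open speak of the compounds shown alone.

Three related compounds have been measured in an assay on mitochondria (strain BALB/c) for inhibition of glycerol-3-phosphate acyltransferase 1, mitochondrial (Mus musculus), read by scintillation counting, with a stated time of 10 min; on this read-out higher numbers stand for weaker inhibition and lower numbers for stronger inhibition. Compound 1 `CCCCCCCCS(=O)(=O)Nc1cc(-c2ccc(CCCC)cc2)ccc1C(=O)O` gives 15700 nM, the lowest of the three numbers, although compound 2 `CCCCCCCCS(=O)(=O)Nc1ccc(-c2ccc(OC)cc2)cc1C(=O)O` with 19500 nM lies within the usual scatter of it. Compound 3 `CCCCCCCCS(=O)(=O)Nc1ccc(C(=O)c2ccccc2OC)cc1C(=O)O` gives 59200 nM. Going by the values given here, the only single-point step among them, a 3.0-fold higher number from compound 2 to compound 3 (0.48 log units; beyond the scatter), came from exchanging 4-methoxyphenyl for (2-methoxyphenyl)carbonyl. Compound 4 `CCCCCCCCS(=O)(=O)Nc1cc(/C=C/c2ccc(OC)cc2)ccc1C(=O)O` differs from compound 1 by 2-(4-methoxyphenyl)ethenyl in place of 4-butylphenyl on an aromatic carbon. Compound 2 shows that a methoxy-bearing ring in place of a butyl-bearing one gives a number close to compound 1, while compound 3 shows that inserting a bridge between the core and the outer ring raised the number. A modest weakening is therefore expected, a 1.6-fold higher number from compound 1 to compound 4 (0.20 log units; within the scatter), giving compound 4 an estimated 25000 nM within 10000 nM to 60000 nM in this assay.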

Compound 4, half-maximal inhibitory concentration: 38700 nM
Compound 4: the middle estimate sits 1.5-fold (0.19 log units) below what was measured; the measured number falls inside the stated range.
By their numbers in this assay, from the lowest: compounds 1, 2, 4 and 3 (each within the scatter of the next, the first and the last beyond it).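

Among the compounds shown, this is the only step at this place, para to a carboxy group, and the swap of 4-butylphenyl for 2-(4-methoxyphenyl)ethenyl raises the number beyond the scatter (a 2.5-fold higher number from compound 1 to compound 4 (0.39 log units; beyond the scatter)). The entering group differs in two ways at once, bringing both a double bond outside the aromatic ring and a hydrogen-bond acceptor, so this single step cannot separate them. No supporting measurement explains the rise. Still open, on these data alone, is how 4-methoxyphenyl or 2-(4-butylphenyl)ethenyl would read at this place, and how an amine on the outer ring would compare.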